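A few compounds are considered here, and "the series" means these few. Any claim that something is new, unique, unknown or untested is made for them only; others in the source may bear on it.

Compounds measured so far:
compound 1 `C#CCOC(=O)/C(C)=C/CC/C(C)=C/CC/C(C)=C/CC[C@@H]1[C@@]2(C)CCC(=O)C(C)(C)[C@H]2CC[C@@]1(C)O` — 114000 nM
compound 2 `C/C(=C\CC/C(C)=C/CC[C@@H]1[C@@]2(C)CCC(=O)C(C)(C)[C@H]2CC[C@@]1(C)O)CC/C=C(\C)C(=O)OCc1cn(-c2ccccc2C)nn1` — > 150000 nM
compound 3 `C/C(=C\CC/C(C)=C/CC[C@@H]1[C@@]2(C)CCC(=O)C(C)(C)[C@H]2CC[C@@]1(C)O)CC/C=C(\C)C(=O)OCc1cn(-c2cccc(F)c2)nn1` — 144000 nM

In a functional assay on MDA-MB-231 cells (Homo sapiens) for antiproliferative activity, read by MTT assay, with a stated time of 48 h (a lower number here means a stronger inhibitor, a higher number a weaker inhibitor), compound 1 gives 114000 nM, the lowest of the two numbers shown; compound 3 sits closest, and the step of a 1.3-fold higher number from compound 1 to compound 3 (0.10 log units; within the scatter) lies within the scatter. For compound 2 only a limit is known, > 150000 nM, so the limit of > 150000 nM in this assay, at which 1 of the 3 values shown sits, applies there. The step of an at least 1.3-fold higher number from compound 1 to compound 2 (0.11 log units; that floor lies within the scatter) is therefore a floor, and an at least 1.0-fold lower number from compound 2 to compound 3 (0.01 log units; that floor lies within the scatter) is likewise only a floor that stays within the scatter. All three measured compounds share the core of compound 1 and differ only in what hangs on the oxygen next to the carbonyl group.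

Compound 4 `C/C(=C\CC/C(C)=C/CC[C@@H]1[C@@]2(C)CCC(=O)C(C)(C)[C@H]2CC[C@@]1(C)O)CC/C=C(\C)C(=O)O` departs from compound 1 by hydrogen in place of propargyl on an oxygen next to a carbonyl group. Within the data shown here, none of the measured steps changes the oxygen next to the carbonyl group from an ester to a carboxy, so no step bears directly on this change; the measured steps only show that exchanging ethynyl for a triazolyl on that chain carbon moved the number little or not beyond the scatter. With no guide, compound 4 is expected to lie near compound 1, the estimated step of a 1.1-fold higher number from compound 1 to compound 4 (0.06 log units; within the scatter) being within the scatter, and compound 4 is estimated at 130000 nM, between 60000 nM and 300000 nM.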

Compound 4, half-maximal inhibitory concentration: 90500 nM
Estimate against measurement, compound 4: 1.4-fold (0.16 log units) above; low and high end bracket the measured number.
By their numbers in this assay, from the lowest: compounds 4, 1 and 3 (each within the scatter of the next). At a limit, above all of these: compound 2.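

In this assay, replacing propargyl with hydrogen on the oxygen next to a carbonyl group, which turns propargyloxycarbonyl into carboxy, gives a 1.3-fold lower number from compound 1 to compound 4 (0.10 log units; within the scatter). The earlier compounds kept the ester and varied only the group on its chain carbon, exchanging ethynyl for a triazolyl; this step removes the whole propargyl and the ester with it, and the result still stays within the scatter, so among the compounds shown neither propargyl nor the ester linkage is needed to reach a number of this size. Nothing measured here gives a reason for this outcome.

As far as these compounds go, whether any group at this oxygen can carry the number beyond the scatter stays open, for example a methyl ester, an amide in place of the ester, or a longer chain ending in an amine. The compounds shown also all carry the same core of compound 1 with its ketone and hydroxy group, so what a change to either of these would do to the number in this assay remains open as well.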